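Methyl in Place of Chloro on Two Related Cores

The source may report more compounds than this note shows. Statements on the series, on what has been measured and on what is new or still open speak of the compounds shown alone.

The measured compounds:
Compound 1, `CC(C)(C)NCc1cc(Cl)cc(Nc2nc3ccccc3[nH]2)c1O`. In an ADME assay on CHO cells (Cricetulus griseus) for inhibition, read by MTT assay (a higher number here means a weaker inhibitor, a lower number a stronger inhibitor), compound 1 gives only a limit, > 50000 nM.
Compound 2, `Cc1cc(CNC(C)(C)C)c(O)c(Nc2nc3ccccc3[nH]2)c1`. In this assay compound 2 gives 33300 nM.
Compound 3, `CCNCc1cc(Cl)cc(Nc2nc3cc(F)c(F)cc3n2Cc2ccc(C(F)(F)F)cc2)c1O`. In this assay compound 3 gives only a limit, > 50000 nM.

Compound 1 and compound 2 differ in one place, (methyl in place of chloro on an aromatic carbon). The step they make, an at least 1.5-fold lower number from compound 1 to compound 2 (0.17 log units; that floor lies within the scatter), is known only as a floor because of the limit of > 50000 nM in this assay, at which 2 of the 3 values shown sit.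

Compound 4, `CCNCc1cc(C)cc(Nc2nc3cc(F)c(F)cc3n2Cc2ccc(C(F)(F)F)cc2)c1O`, has not yet been measured. It stands to compound 3 as compound 2 stands to compound 1: methyl in place of chloro on an aromatic carbon. The two "place" descriptions are not identical, since in compound 1 the exchanged atom sits meta to a ((tert-butyl)amino)methyl group (6 heavy atoms) and in compound 3 meta to a (ethylamino)methyl group (4 heavy atoms), so the change is the same kind of change rather than the same one. The difference between the core of compound 1 and the core of compound 3 is not broken down here.

For compound 4 in this assay the expected step is an at least 1.2-fold lower number from compound 3 to compound 4 (0.09 log units; that floor lies within the scatter), resting on the floor that compound 1 and compound 2 set with an at least 1.5-fold lower number from compound 1 to compound 2 (0.17 log units; that floor lies within the scatter) and on the limit compound 3 gives, > 50000 nM. Compound 4 is therefore estimated at 40000 nM, with an expected range from 12000 nM to 120000 nM, and a fair chance that only a limit is reported again.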

Compound 4, half-maximal inhibitory concentration: 2040 nM
For compound 4 the middle estimate is 20-fold (1.29 log units) above the measured one; measured number below the stated range.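

In this assay, methyl in place of chloro, on an aromatic carbon para to a hydroxy group, comes with an at least 24-fold lower number from compound 3 to compound 4 (1.38 log units; beyond the scatter), so on the core of compound 3 the change marks a large move towards stronger inhibition. Set beside the earlier step, the change lowers the number on both cores, yet this does not show that it acts to the same extent on each: the same change on two cores in this assay, an at least 1.5-fold lower number (0.17 log units; that floor lies within the scatter) from compound 1 to compound 2 and an at least 24-fold lower number (1.38 log units; beyond the scatter) from compound 3 to compound 4; the limit leaves it open whether they differ. Both steps are known only as floors, and two cores give no rule for how much of the change carries to a further core, because the chloro compounds both sit at the limit of the assay: the limit of > 50000 nM in this assay, at which 2 of the 4 values shown sit.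

The compounds shown leave open whether the large step on the core of compound 4 belongs to methyl in particular or would also appear with a fluoro, methoxy or ethyl group in the place of the chloro. They also leave open which part of the core of compound 3 goes with the large step, whether the (ethylamino)methyl group or the rest of that core, since the cores differ in more than one place.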